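Pyrazolyl to methoxyphenyl on the amine nitrogen

A few compounds are considered here, and "the series" means these few. Any claim that something is new, unique, unknown or untested is made for them only; others in the source may bear on it.

Measured in a functional assay on HeLa cells (Homo sapiens) for antiproliferative activity, read by MTT assay, with a stated time of 72 h; on this read-out lower numbers stand for stronger inhibition and higher numbers for weaker inhibition:
Compound 1 `CC(C)=CC(=O)Nc1cccc(Oc2nc(Nc3ccn(C)n3)nc3c2CSCC3)c1`: > 50000 nM (a limit)
Compound 2 `C=C(C)C(=O)Nc1cccc(Oc2nc(Nc3ccn(C)n3)nc3c2CSCC3)c1`: > 50000 nM (a limit)
Not yet measured:
Compound 3 `COc1ccc(Nc2nc3c(c(Oc4cccc(NC(=O)C=C(C)C)c4)n2)CSCC3)cc1`

Compound 1 gives only a limit in this assay, not a number. Compound 2 gives only a limit as well, so the whole picture so far is the limit of > 50000 nM in this assay, at which 2 of the 2 values shown sit.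

The change to compound 3 is 4-methoxyphenyl in place of 1-methyl-1H-pyrazol-3-yl on a nitrogen on an aromatic ring. In short, 4-methoxyphenyl comes in place of 1-methyl-1H-pyrazol-3-yl on a nitrogen on an aromatic ring, and the rest of compound 1 stays as it is.

Within the data shown here, the only measured step is a step that the two limits leave unreadable from compound 1 to compound 2. It lies at a different place, on a carbonyl carbon, and offers no size to carry over to this exchange. Among the measured compounds shown here, no measured step therefore speaks to the change directly. Any shift that could be read would have to be towards stronger inhibition, and compound 3 may well stay at the same limit.

The expected step is an at least 1.6-fold lower number from compound 1 to compound 3 (0.22 log units; that floor lies within the scatter), a modest one at best. For compound 3 the estimated value is 30000 nM, with an expected range from 6000 nM to 70000 nM.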

Compound 3, half-maximal inhibitory concentration: 19100 nM
Compound 3: the middle estimate sits 1.6-fold (0.20 log units) above what was measured; low and high end bracket the measured number.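

In this assay, among these compounds, the nitrogen on an aromatic ring proves to be a place that responds: 4-methoxyphenyl in place of 1-methyl-1H-pyrazol-3-yl gives an at least 2.6-fold lower number from compound 1 to compound 3 (0.41 log units; beyond the scatter) and is the first readable change. Compound 1 gives > 50000 nM, which is a limit, so the size of this step is only a floor, and the step on the carbonyl carbon between the two compounds held at the limit cannot be read. Among the compounds shown here, compound 3 is the only compound here with a number, 19100 nM. Compound 1 and compound 2 share one read-out: the limit of > 50000 nM in this assay, at which 2 of the 3 values shown sit.

On these data alone, it remains open whether the gain needs the methoxy group at all or comes with the carbon-only aromatic ring itself, a question that a plain phenyl or a 4-chlorophenyl on the same nitrogen would address. Also open, as far as these compounds go, is whether the 1-methylethenyl group of compound 2 would give a similar number with 4-methoxyphenyl on the nitrogen, so the two places cannot yet be judged together.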